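The source may hold more compounds than are shown below. What is called first, only, known or untested is meant among the compounds shown, and "the series" means these compounds.

Measured compounds:
compound 1 `COc1ccc(-c2ccc(-c3ccc(C(=N)N)cc3)s2)cc1`: 183 nM
compound 2 `N=C(N)c1ccc(-c2ccc(-c3ccc(Cl)cc3)s2)cc1F`: 172 nM
compound 3 `COc1cc(OC)cc(-c2ccc(-c3ccc(C(=N)N)c(F)c3)s2)c1`: 196 nM

All three values come from a functional assay on HCT-15 cells (Homo sapiens) for inhibition, read by sulforhodamine B assay, with a stated time of 48 h; on this read-out lower numbers stand for stronger inhibition of growth and higher numbers for weaker inhibition of growth. Compound 1 holds the second highest of the three numbers; its nearest neighbour is compound 2 and its furthest is compound 3, and both of those gaps are within the scatter, so the three compounds cannot be ordered on these data.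

Compound 4 `COc1ccc(-c2ccc(-c3ccc(C(=N)N)c(F)c3)s2)cc1` is not yet measured. Compared with compound 1 the change is fluoro in place of hydrogen on an aromatic carbon. The fluoro enters on an aromatic carbon of a six-membered aromatic ring of carbon only, ortho to a group of 3 heavy atoms and meta to a large group.

Going by the values given here, no step between measured compounds is available for this change. Compounds 2 and 3 both carry the fluoro at the corresponding place and give numbers within the scatter of compound 1, so in this assay no step beyond the scatter is expected in either direction. Compound 4 is estimated at 185 nM, with a range from 110 nM to 320 nM, which corresponds to an expected step of a 1.0-fold higher number from compound 1 to compound 4 (0.00 log units; within the scatter).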

Compound 4, concentration for 50% growth inhibition: 2580 nM
The estimate for compound 4 lay 14-fold (1.14 log units) below the measured number; measured number outside the range, above it.
By their numbers in this assay, from the lowest: compounds 2, 1 and 3 (each within the scatter of the next); then compound 4.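

In this assay, fluoro in place of hydrogen on this aromatic carbon is not a neutral change on the core of compound 1: a 14-fold higher number from compound 1 to compound 4 (1.15 log units; beyond the scatter). With the fluoro held constant, methoxy in place of chloro gives a 15-fold higher number from compound 2 to compound 4 (1.18 log units; beyond the scatter), so the fluoro is tolerated in one setting and not in another among single-place comparisons. Methoxy with fluoro is no general liability, however: compound 3 carries the fluoro and two methoxy groups and gives 196 nM, which goes against such a pattern.

No measurement at hand bears on the reason for these steps. Going by these compounds, it remains open whether a methyl group or a chloro at the fluoro position would give the same result on the core of compound 1, and whether a hydroxy group or an amine in place of methoxy would keep the higher number of compound 4.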